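Compound 3: pyridin-2-yl in place of 4-fluorophenyl

The source may report more compounds than this note shows. Statements on the series, on what has been measured and on what is new or still open speak of the compounds shown alone.

Measured in an ADME assay on BHK-21 cells (Mesocricetus auratus) for cytotoxicity, read by MTT assay, with a stated time of 120 h; on this read-out higher numbers stand for lower toxicity in this test and lower numbers for higher toxicity in this test:
Compound 1 `O=C1C2=C(SCCS2)C(=O)N1CCCCN1CCN(c2ccccc2)CC1`: > 100000 nM
Compound 2 `O=C1C2=C(SCCS2)C(=O)N1CCCCN1CCN(c2ccc(F)cc2)CC1`: > 100000 nM

Compound 2 gives > 100000 nM in this assay, and this is a limit of the assay, not a number. Compound 1 gives > 100000 nM, which is likewise a limit. The next compound, compound 3 `O=C1C2=C(SCCS2)C(=O)N1CCCCN1CCN(c2ccccn2)CC1`, carries pyridin-2-yl in place of 4-fluorophenyl on an amine nitrogen in a ring.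

Among the compounds with values here, only one measured step bears on this change, and it sits at a different kind of replacement, fluoro in place of hydrogen on an aromatic carbon. That step is a step that the two limits leave unreadable from compound 1 to compound 2, so it offers no size to carry over. The remaining guide is the limit of > 100000 nM in this assay, at which 2 of the 2 values shown sit. On that basis, no step beyond the usual scatter is expected in this assay, and another limit is the likeliest report. The expected change is a number no higher from compound 2 to compound 3 (the limit leaves the size open). Compound 3 is estimated at 100000 nM, with an expected range of 50000 nM to 200000 nM.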

Compound 3, half-maximal cytotoxic concentration: > 100000 nM
Compound 3: no number, only a limit; the forecaster's own chance of this, stated with the estimate: 80%; the middle value lies on the limit itself.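

In this assay compound 3 gives > 100000 nM, which is a limit of the assay and not a number. Within the data shown here, no step among compound 1, compound 2 and compound 3 can be read. The compounds shown leave open whether phenyl, 4-fluorophenyl and pyridin-2-yl differ at all in this test, and the only guide is a shared ceiling: the limit of > 100000 nM in this assay, at which 3 of the 3 values shown sit.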